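Iodo for Bromo on the Saturated Ring of Compound 2

A few compounds are considered here, and "the series" means these few. Any claim that something is new, unique, unknown or untested is made for them only; others in the source may bear on it.

Measured compounds:
compound 1 `Nc1nc(=O)n(C2OC(CO)C(I)C2O)cc1F` — 8 ug/mL
compound 2 `Nc1ccn(C2OC(CO)C(Br)C2O)c(=O)n1` — > 100 ug/mL
compound 3 `Nc1nc(=O)n(C2OC(CO)C(Br)C2O)cc1F` — 5 ug/mL

In a functional assay on P815 cells (Mus musculus) for antiproliferative activity (on this read-out lower numbers stand for stronger inhibition and higher numbers for weaker inhibition), compound 1 gives 8 ug/mL and compound 3 gives 5 ug/mL. For compound 2 the assay gives only > 100 ug/mL, which is a limit of the assay and not a number. Compound 2 therefore sits at the limit of > 100 ug/mL in this assay, at which 1 of the 3 values shown sits, and its position among the three can be given no more closely than that.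

Two single-change steps connect the measured compounds: a 1.6-fold lower number from compound 1 to compound 3 (0.20 log units; within the scatter) and an at least 20-fold lower number from compound 2 to compound 3 (1.30 log units; beyond the scatter).

Compound 4 `Nc1ccn(C2OC(CO)C(I)C2O)c(=O)n1` is not yet measured. It differs from compound 2 by iodo in place of bromo on a saturated ring carbon. The step that bears on this change is a 1.6-fold lower number from compound 1 to compound 3 (0.20 log units; within the scatter), the same swap of halogen in the opposite direction, and it lies within the scatter. No step beyond the scatter is therefore expected in this assay from compound 2 to compound 4, and compound 4 is most likely expected to remain at the limit as well. Compound 4 is estimated at 150 ug/mL, with a range from 50 ug/mL to 500 ug/mL, which means an expected step that the limit leaves unreadable from compound 2 to compound 4.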

Compound 4, concentration for 50% inhibition: > 100 ug/mL
Compound 4 gave a limit, no number; the forecaster's own chance of this, stated with the estimate: 80%; the middle value does not contradict the limit.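

In this assay compound 4 gives > 100 ug/mL, which is a limit of the assay and not a number. The step between compound 2 and compound 4 therefore cannot be read, so iodo in place of bromo on this saturated ring carbon can be sized only on the fluoro core, while on the core with hydrogen on the aromatic carbon both halogens leave the same limit: the limit of > 100 ug/mL in this assay, at which 2 of the 4 values shown sit. Hydrogen in place of fluoro gives an at least 12-fold higher number from compound 1 to compound 4 (1.09 log units; beyond the scatter), so this change, so far seen only with bromo, now also stands beyond the scatter with iodo: the same change on two cores in this assay, an at least 20-fold lower number (1.30 log units; beyond the scatter) from compound 2 to compound 3 and an at least 12-fold lower number (1.09 log units; beyond the scatter) from compound 4 to compound 1; the limit leaves it open whether they differ.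

The compounds shown leave open how far the sizes of those two fluoro steps differ. They also leave open how the fluoro core would respond to an amine or an azido group on this saturated ring carbon in place of the halogen.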